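The source may report more compounds than this note shows. Statements on the series, on what has been measured and on what is new or still open speak of the compounds shown alone.

In an assay on isolated protein for inhibition of malate dehydrogenase, mitochondrial (Sus scrofa), with stated times of 45 min and 30 min (a lower number here means a stronger inhibitor, a higher number a weaker inhibitor), compound 1 `O=S(=O)(Nc1ccc2oc(-c3ccccc3)nc2c1)c1cccs1` gives > 63000 nM, which is a limit of the assay and not a number. Compound 2 `CS(=O)(=O)Nc1ccc2oc(-c3ccccc3)nc2c1` gives > 63000 nM in this assay, again a limit rather than a number. Compound 3 `O=S(=O)(Nc1ccc2oc(-c3ccccc3)nc2c1)c1cccc(O)c1` likewise gives > 63000 nM in this assay, a limit and not a number. All three compounds share one core and differ only in the group on the sulfonyl sulfur, so that the limit of > 63000 nM in this assay, at which 3 of the 3 values shown sit, describes the whole of what is known: the step from compound 1 to compound 2 is a step that the two limits leave unreadable from compound 1 to compound 2, the step from compound 1 to compound 3 is a step that the two limits leave unreadable from compound 1 to compound 3, and the step from compound 2 to compound 3 is a step that the two limits leave unreadable from compound 2 to compound 3. Within the data shown here, compound 3 therefore stands at the same limit as the two others, and no measured step gives a size to read.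

Compound 4 `O=S(=O)(Nc1ccc2oc(-c3ccccc3)nc2c1)c1ccccc1F` has not yet been measured in this assay. It differs from compound 3 as follows: 2-fluorophenyl in place of 3-hydroxyphenyl on a sulfonyl sulfur. Among the measured compounds shown here, no measured step bears on this exchange, and with every value shown sitting at a limit, no direction beyond the scatter can be expected for the step from compound 3 to compound 4, which is estimated as a step that the limit leaves unreadable from compound 3 to compound 4. Compound 4 is accordingly expected to give about 80000 nM in this assay, within a range from 20000 nM to 300000 nM, most probably reported again only as a limit.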

Compound 4, half-maximal inhibitory concentration: > 63000 nM
Compound 4: no number, only a limit; the forecaster's own chance of this, stated with the estimate: 75%; the middle value is on the limit's open side.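

In this assay compound 4 gives > 63000 nM as a limit and not a number. Among these compounds, no step from compound 1, compound 2 or compound 3 to compound 4 can be read, and the series stays at one limit: the limit of > 63000 nM in this assay, at which 4 of the 4 values shown sit. The compounds shown leave open whether any group on the sulfonyl sulfur of the shared core gives a measurable inhibition.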